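The source may hold more compounds than are shown below. What is called first, only, known or untested is meant among the compounds shown, and "the series" means these compounds.

Measured compounds:
Compound 1, `COc1ccc(C(=O)C2Sc3nnc(-c4cc(OC)c(OC)c(OC)c4)n3NC2c2ccco2)cc1` — in a functional assay on MCF7 cells (Homo sapiens) for cytotoxicity, read by MTT assay, with a stated time of 48 h (a lower number here means a stronger inhibitor, a higher number a weaker inhibitor), compound 1 gives > 100000 nM, which is a limit of the assay rather than a number.
Compound 2, `COc1cc(-c2nnc3n2NC(c2ccco2)C(C(=O)c2ccc(C)cc2)S3)cc(OC)c1OC` — compound 2 gives > 100000 nM, also only a limit.
Compound 3, `COc1cc(-c2nnc3n2NC(c2ccco2)C(C(=O)c2ccccc2F)S3)cc(OC)c1OC` — compound 3 gives 94800 nM.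

Compound 1 thus stands only at a limit, as the limit of > 100000 nM in this assay, at which 2 of the 3 values shown sit, describes. The step to compound 4, `COc1cc(C(=O)C2Sc3nnc(-c4cc(OC)c(OC)c(OC)c4)n3NC2c2ccco2)cc(OC)c1OC`, alters the aryl group on the carbonyl carbon: 3,4,5-trimethoxyphenyl in place of 4-methoxyphenyl on a carbonyl carbon. Two measured steps change the same group: an at least 1.0-fold lower number from compound 1 to compound 3 (0.02 log units; that floor lies within the scatter) and an at least 1.0-fold lower number from compound 2 to compound 3 (0.02 log units; that floor lies within the scatter), both floors within the scatter, while a step that the two limits leave unreadable from compound 1 to compound 2. Every measured value sits at or close to the limit, so none of these steps shows movement beyond the scatter, and none is expected for compound 4. Compound 4 is therefore estimated at 100000 nM, with a range of 50000 nM to 300000 nM, which would mean a number no higher from compound 1 to compound 4 (the limit leaves the size open); most likely the assay would again report only a limit.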

Compound 4, half-maximal inhibitory concentration: > 100000 nM
Compound 4: no number, only a limit (the forecaster's own chance of this, stated with the estimate: 70%); the middle value lies on the limit itself.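

Even with 3,4,5-trimethoxyphenyl on the carbonyl carbon, compound 4 gives no number in this assay, so this larger group does not bring the series clear of the limit. For the compounds shown here, the one step that can be read is an at least 1.0-fold higher number from compound 3 to compound 4 (0.02 log units; that floor lies within the scatter), while the steps from compound 1 and compound 2 to compound 4 cannot be read. All four aryl groups at this position now leave the result at or close to the same edge: the limit of > 100000 nM in this assay, at which 3 of the 4 values shown sit.

From the compounds shown here alone, how compound 1, compound 2 and compound 4 rank among themselves stays open. So does whether an aryl group carrying an amine or a carboxylic acid on this carbonyl carbon would give a value clearly away from the limit.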